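This account rests on a few compounds, and the source may have more. Where it says the series, first, only, none or still open, it means among the compounds named here.

Measured compounds, cytotoxicity in a functional assay on HCT-116 cells (Homo sapiens) for cytotoxicity, read by MTT assay, with a stated time of 72 h; a lower number here means a stronger inhibitor, a higher number a weaker inhibitor:

- compound 1 `CNCCN(C)Cc1ccc(-c2ccnc3ccc(-c4cnc(OC)c(NS(=O)(=O)c5ccc(F)cc5F)c4)cc23)cc1` gives 51.8 nM
- compound 2 `COc1ncc(-c2ccc3nccc(-c4ccc(CN5CCCCC5)cc4)c3c2)cc1NS(=O)(=O)c1ccc(F)cc1F` gives 34.1 nM
- compound 3 `COc1ncc(-c2ccc3nccc(-c4ccc(CN5CCN(C)CC5)cc4)c3c2)cc1NS(=O)(=O)c1ccc(F)cc1F` gives 43.9 nM

Compound 3 stands second highest of the three numbers; its nearest neighbour is compound 1, its furthest compound 2, and a 1.2-fold lower number from compound 1 to compound 3 (0.07 log units; within the scatter) as well as a 1.3-fold higher number from compound 2 to compound 3 (0.11 log units; within the scatter) lie within the scatter, as does a 1.5-fold lower number from compound 1 to compound 2 (0.18 log units; within the scatter). All three measured steps exchange the amine on the saturated chain carbon bound to the aromatic carbon, and none of them moves the number beyond the scatter.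

Compound 4 `COc1ncc(-c2ccc3nccc(-c4ccc(CN5CCN(C(C)C)CC5)cc4)c3c2)cc1NS(=O)(=O)c1ccc(F)cc1F` differs from compound 3 by isopropyl in place of methyl on an amine nitrogen in a ring. Among the compounds with values here, no measured step touches the substituent on that ring nitrogen, so the only guide is the indifference of this assay to the three amine variants so far. The expectation is therefore no step beyond the scatter, a 1.0-fold higher number from compound 3 to compound 4 (0.01 log units; within the scatter), for compound 4. Compound 4 is estimated at 45 nM in this assay, with a range from 20 nM to 100 nM.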

Compound 4, half-maximal inhibitory concentration: 24.7 nM
Beside the measured number, compound 4's estimate is 1.8-fold (0.26 log units) above it; measured number inside the range.
By their numbers in this assay, from the lowest: compounds 4, 2, 3 and 1 (each within the scatter of the next, the first and the last beyond it).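

In this assay the ring nitrogen three ring bonds from the ring atom that bears a large group holds isopropyl as well as methyl, with a 1.8-fold lower number from compound 3 to compound 4 (0.25 log units; within the scatter) showing no separation, and the whole 4-isopropylpiperazin-1-yl group stands level with piperidin-1-yl, with a 1.4-fold lower number from compound 2 to compound 4 (0.14 log units; within the scatter) as the step. Within the data shown here, the first step beyond the scatter in the set appears only against the methyl(2-(methylamino)ethyl)amino group, with a 2.1-fold lower number from compound 1 to compound 4 (0.32 log units; beyond the scatter) as a modest gap, while compound 1 stays within the scatter of compound 2 and compound 3. No available evidence bears on what lies behind these numbers.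

Going by these compounds, whether a cyclopropyl group, an acetyl group or a longer chain on that ring nitrogen would part from compound 4 remains open. So does whether the flat response to these amines holds outside this single cell assay.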